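The source may hold more compounds than are shown below. What is called first, only, known or untested is meant among the compounds shown, and "the series" means these compounds.

In a functional assay on HCT-116 cells (Homo sapiens) for antiproliferative activity, read by MTT assay, with a stated time of 72 h (on this read-out lower numbers stand for stronger inhibition and higher numbers for weaker inhibition), compound 1 `COc1ccc(NC(=O)CCc2cccc3c2B(O)OC3)cc1` gives 1700 nM, while compound 2 `C#Cc1cccc(NC(=O)CCc2cccc3c2B(O)OC3)c1` gives 3600 nM, the highest of the two numbers recorded, with compound 1 the nearer of the pair. Compound 3 `O=C(CCc1cccc2c1B(O)OC2)Nc1cccc(-c2ccc(C(F)(F)F)cc2)c1` has not yet been tested in this assay. It differs from compound 2 in one place: 4-(trifluoromethyl)phenyl in place of ethynyl on an aromatic carbon. Going by the values given here, no measured pair shows a change of this kind, so the expectation rests on the two numbers alone. The step from compound 2 to compound 3 in this assay is expected to be modest and towards a lower number, a 2.4-fold lower number from compound 2 to compound 3 (0.38 log units; beyond the scatter). Compound 3 is estimated at 1500 nM, within a range from 400 nM to 5500 nM.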

Compound 3, half-maximal inhibitory concentration: 550 nM
Estimate against measurement, compound 3: 2.7-fold (0.44 log units) above, within the range that was stated.
By their numbers in this assay, from the lowest: compound 3; then compound 1; then compound 2.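

In this assay, going by these compounds alone, the exchange of ethynyl for 4-(trifluoromethyl)phenyl gives a 6.5-fold lower number from compound 2 to compound 3 (0.82 log units; beyond the scatter) and is the first single-place change available. This aromatic carbon, meta to a large group, therefore tolerates a far larger group carrying its own six-membered aromatic ring, and the number falls rather than rises. Nothing measured here bears on why the number falls. From the compounds shown here alone, it remains open whether a plain phenyl, a pyridine ring or an amine on this carbon would give a similar number. The share of the trifluoromethyl group in this step also remains undefined.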